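From 2-methylphenyl to 3-chlorophenyl on a shared core

A few compounds are considered here, and "the series" means these few. Any claim that something is new, unique, unknown or untested is made for them only; others in the source may bear on it.

In a functional assay on HT-29 cells (Homo sapiens) for antiproliferative activity, read by sulforhodamine B assay, with a stated time of 72 h (on this read-out higher numbers stand for weaker inhibition and lower numbers for stronger inhibition), compound 1 (`NC(=S)N/N=C/c1ccc2ccccc2n1`), with hydrogen on the amide-type nitrogen, gives 100000 nM. Compound 2 (`Cc1ccc(NC(=S)N/N=C/c2ccc3ccccc3n2)cc1`), with 4-methylphenyl on that nitrogen, gives 85500 nM, which amounts to a 1.2-fold lower number from compound 1 to compound 2 (0.07 log units; within the scatter). Compound 3 (`Cc1ccccc1NC(=S)N/N=C/c1ccc2ccccc2n1`), with 2-methylphenyl there instead, gives 42300 nM, the lowest number of the three and so the strongest inhibition seen so far. Its gain over the unsubstituted parent is a 2.4-fold lower number from compound 1 to compound 3 (0.37 log units; beyond the scatter).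

Compound 4 (`S=C(N/N=C/c1ccc2ccccc2n1)Nc1cccc(Cl)c1`) keeps the shared core but has 3-chlorophenyl in place of 2-methylphenyl on the amide-type nitrogen: 3-chlorophenyl in place of 2-methylphenyl on an amide-type nitrogen. Among the compounds with values here, no compound measured so far carries chlorine, so the data offer no direct guide to this group. Within the data shown here, the nearest precedent is the exchange of one substituted phenyl for another, a 2.0-fold lower number from compound 2 to compound 3 (0.31 log units; beyond the scatter), and that step is modest. A similar exchange here might therefore move the number only slightly, and nothing measured favours either direction. The estimated change is a 1.1-fold lower number from compound 3 to compound 4 (0.02 log units; within the scatter), so no clear step beyond the scatter is expected. Compound 4 is expected to give about 40000 nM, with an estimated range from 15000 nM to 100000 nM.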

Compound 4, half-maximal inhibitory concentration: 48100 nM
Estimate against measurement, compound 4: 1.2-fold (0.08 log units) below, within the range that was stated.
By their numbers in this assay, from the lowest: compounds 3, 4, 2 and 1 (each within the scatter of the next, the first and the last beyond it).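

Exchanging 2-methylphenyl for 3-chlorophenyl on the amide-type nitrogen gives no readable change in this assay (a 1.1-fold higher number from compound 3 to compound 4 (0.06 log units; within the scatter)), so at this position a chlorine-bearing phenyl ring and a methyl-bearing one cannot be told apart in this pair. The comparison with 4-methylphenyl (a 1.8-fold lower number from compound 2 to compound 4 (0.25 log units; within the scatter)) also stays within the scatter, whereas the step from that group to 2-methylphenyl (a 2.0-fold lower number from compound 2 to compound 3 (0.31 log units; beyond the scatter)) lies just beyond it, so compound 4 cannot be separated from either compound 2 or compound 3. Only against hydrogen on that nitrogen does compound 4 show a difference beyond the scatter (a 2.1-fold lower number from compound 1 to compound 4 (0.32 log units; beyond the scatter)), a modest one that matches the size of the gain seen with compound 3, and no supporting measurement bears on the reason for any of these steps.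

Within the data shown here, every step so far is modest or smaller, and it remains open whether a different kind of group on this nitrogen, such as a longer carbon chain or a phenyl ring bearing a carboxylic acid, would produce a larger one. Also open, on these data alone, is whether changes to the shared core itself would matter more than changes at this position.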